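The source may hold more compounds than are shown below. What is called first, only, known or untested is meant among the compounds shown, and "the series" means these compounds.

Three compounds sharing one core were tested in an assay on membranes from CHO cells for displacement of a labelled ligand from adenosine receptor A1 (Homo sapiens), read by scintillation counting, with a stated time of 60 min, tested at 1 uM; a lower number here means less inhibition, a higher number more inhibition at the concentration tested (going by the name of the read-out). Compound 1 `CC1=C(C(=O)C2CC2)C(c2ccoc2)NC(=O)N1` gives 1%. Compound 2 `CCN(CC)C(=O)C1=C(C)NC(=O)NC1c1ccoc1` gives 15%, and compound 3 `CCSC(=O)C1=C(C)NC(=O)NC1c1ccoc1` gives 3%. On these numbers compound 3 stands second of the three: its nearest neighbour lies within the scatter, a number 2 percentage points higher from compound 1 to compound 3 (within the scatter), while the only separation beyond the scatter is a number 12 percentage points lower from compound 2 to compound 3 (beyond the scatter). Compound 4 `CC1=C(C(=O)OC2CCC2)C(c2ccoc2)NC(=O)N1` differs from compound 3 by cyclobutyloxy in place of ethylsulfanyl on a carbonyl carbon. Within the data shown here, the steps bearing on this carbonyl carbon, a number 14 percentage points higher from compound 1 to compound 2 (beyond the scatter) and a number 2 percentage points higher from compound 1 to compound 3 (within the scatter), were at most modest, and all values so far are low, so the expected step, a number 1 percentage points higher from compound 3 to compound 4 (within the scatter), is none beyond the scatter in this assay. Compound 4 is therefore estimated at 4%, within 0% to 15%.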

Compound 4, a percentage reported as inhibition, at one concentration (the size of the read-out at that concentration, not a potency): 20%
For compound 4 the middle estimate is 16 percentage points below the measured one; measured number above the stated range.
By their numbers in this assay, from the lowest: compounds 1 and 3 (each within the scatter of the next); then compounds 2 and 4 (each within the scatter of the next).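

In this assay, among these compounds, the step with cyclobutyloxy in place of ethylsulfanyl is a number 17 percentage points higher from compound 3 to compound 4 (beyond the scatter) and the step with cyclobutyloxy in place of cyclopropyl is a number 19 percentage points higher from compound 1 to compound 4 (beyond the scatter) on the same carbonyl carbon, so diethylamino is no longer the only group here to stand clear of the others. Cyclobutyloxy in place of diethylamino gives a number 5 percentage points higher from compound 2 to compound 4 (within the scatter) and so does not separate these two different groups. Nothing available explains these steps. Open, from the compounds shown here alone, is how a cyclopentyloxy, an open-chain butyloxy or a carboxylic acid on this carbonyl carbon would compare with cyclobutyloxy.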